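Swapping a Chlorophenyl for a Fluorophenyl on a Thiourea

A few compounds are considered here, and "the series" means these few. Any claim that something is new, unique, unknown or untested is made for them only; others in the source may bear on it.

Three thiosemicarbazones have results in a functional assay on HL-60 cells (Homo sapiens) for antiproliferative activity, read by sulforhodamine B assay, with a stated time of 72 h; a higher number here means a weaker inhibitor, a lower number a stronger inhibitor. Compound 1 `COc1ccc(C)cc1NC(=S)N/N=C/c1ccc2ccccc2n1` gives > 100000 nM, which is a limit of the assay and not a number. Compound 3 `NC(=S)N/N=C/c1cc2cccnc2s1` gives > 100000 nM, again a limit rather than a measured number. For the measured compounds named here, compound 2 `S=C(N/N=C/c1ccc2ccccc2n1)Nc1cccc(Cl)c1` is the one compound with a real number, 28800 nM in this assay, so it stands alone: the other two results sit at the limit of > 100000 nM in this assay, at which 2 of the 3 values shown sit, and no comparison of measured steps can be drawn.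

Compound 4 `Fc1ccc(NC(=S)N/N=C/c2ccc3ccccc3n2)cc1` has not yet been measured. It differs from compound 2 by 4-fluorophenyl in place of 3-chlorophenyl on an amide-type nitrogen. Going by the values given here, because the only number at hand is the weak 28800 nM of compound 2, and because both neighbours sit at the limit of > 100000 nM in this assay, at which 2 of the 3 values shown sit, the step from compound 2 to compound 4 is expected to be a small loss, a 2.1-fold higher number from compound 2 to compound 4 (0.32 log units; beyond the scatter), likely within the scatter of repeated measurements. Compound 4 is therefore estimated at 60000 nM in this assay, with a range from 20000 nM to 150000 nM.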

Compound 4, half-maximal inhibitory concentration: 17000 nM
The estimate for compound 4 lay 3.5-fold (0.55 log units) above the measured number, outside the stated range (below it).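

In this assay, putting 4-fluorophenyl in place of 3-chlorophenyl on the amide-type nitrogen gives a 1.7-fold lower number from compound 2 to compound 4 (0.23 log units; within the scatter), so the two compounds cannot be told apart. This position therefore accepts two different halogen-bearing phenyl groups, and each gives a real number rather than a limit. Compound 1, with a different substituted phenyl at this place, gives > 100000 nM, a limit of the assay and not a number, so a readable value does not follow from having just any substituted phenyl there: the limit of > 100000 nM in this assay, at which 2 of the 4 values shown sit.

The compounds shown leave open whether a halogen on the phenyl matters at all, as an unsubstituted phenyl would test. They also do not say whether the ring itself can be replaced on this nitrogen, for instance by a cyclohexyl group or a short alkyl chain.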